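Difluorophenyl chalcone-pyrazole: expected cytotoxicity from two precedents

The compounds below may be only part of what the source reports. "The series", "measured", "known", "first", "only" and "open" are said of these compounds alone.

Measured so far in a functional assay on BT-549 cells (Homo sapiens) for inhibition, read by sulforhodamine B assay, with a stated time of 48 h; a higher number here means that more compound is tolerated, a lower number that less compound is tolerated:
Compound 1 `COc1cc(-c2cc(/C=C/C(=O)c3ccc(Cl)c(Cl)c3)[nH]n2)cc(OC)c1OC`: 92600 nM
Compound 2 `COc1ccc(C(=O)/C=C/c2cc(-c3cc(OC)c(OC)c(OC)c3)n[nH]2)cc1OC`: 5870 nM

Compound 2 gives the lowest of the two numbers in this assay; compound 1 sits a 16-fold lower number from compound 1 to compound 2 (1.20 log units; beyond the scatter) away. Compound 3 `COc1cc(-c2cc(/C=C/C(=O)c3ccc(F)c(F)c3)[nH]n2)cc(OC)c1OC` differs from compound 2 by 3,4-difluorophenyl in place of 3,4-dimethoxyphenyl on a carbonyl carbon. Within the data shown here, the one step that bears on it is the earlier exchange at the same carbonyl carbon, a 16-fold lower number from compound 1 to compound 2 (1.20 log units; beyond the scatter), which shows the 3,4-dimethoxyphenyl group giving the lower number. Moving away from it toward a 3,4-dihalogenated ring is therefore expected to raise the number, a 6.8-fold higher number from compound 2 to compound 3 (0.83 log units; beyond the scatter), and compound 3 is estimated at 40000 nM (range 10000 nM to 120000 nM).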

Compound 3, concentration lethal to 50% of the cells: 79500 nM
The estimate for compound 3 lay 2.0-fold (0.30 log units) below the measured number, and the stated range covers the measured number.
By their numbers in this assay, from the lowest: compound 2; then compounds 3 and 1 (each within the scatter of the next).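

In this assay, the 3,4-difluorophenyl group on this carbonyl carbon does not keep the low number seen with the 3,4-dimethoxyphenyl group (a 14-fold higher number from compound 2 to compound 3 (1.13 log units; beyond the scatter)). The 3,4-dichlorophenyl and 3,4-difluorophenyl groups cannot be told apart at this place (a 1.2-fold lower number from compound 1 to compound 3 (0.07 log units; within the scatter)), so among these three compounds only the 3,4-dimethoxyphenyl group stands apart. No measurement offered here accounts for this difference. Whether both methoxy groups are needed remains open, since a ring with a single methoxy group is not among these compounds. From the compounds shown here alone, how an amine or a carboxylic acid on this ring would read also remains open.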